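A few compounds are considered here, and "the series" means these few. Any claim that something is new, unique, unknown or untested is made for them only; others in the source may bear on it.

In a functional assay on PC-3 cells (Homo sapiens) for antiproliferative activity, read by MTT assay, with a stated time of 48 h (a higher number here means a weaker inhibitor, a lower number a stronger inhibitor), compound 3 `C#CCCOC(=O)c1ccc(C(CC)(CC)c2ccc(OCCC(O)(CC)CC)c(C)c2)n1CC` is reported only as a limit, > 50000 nM. Two related compounds give numbers. Compound 1 `CCN(CC)CCNC(=O)c1ccc(C(CC)(CC)c2ccc(OCCC(O)(CC)CC)c(C)c2)n1CC` gives 3350 nM, and compound 2 `CCn1c(C(=O)NCCN)ccc1C(CC)(CC)c1ccc(OCCC(O)(CC)CC)c(C)c1` gives 2420 nM, with a 1.4-fold lower number from compound 1 to compound 2 (0.14 log units; within the scatter). In compound 4 `CCOc1ccc(NC(=O)c2ccc(C(CC)(CC)c3ccc(OCCC(O)(CC)CC)c(C)c3)n2CC)cc1`, (4-ethoxyphenyl)amino stands in place of (but-3-yn-1-yl)oxy on a carbonyl carbon ((4-ethoxyphenyl)amino in place of (but-3-yn-1-yl)oxy on a carbonyl carbon).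

The measured changes at that same carbonyl carbon are an at least 14-fold higher number from compound 1 to compound 3 (1.17 log units; beyond the scatter) and an at least 20-fold higher number from compound 2 to compound 3 (1.31 log units; beyond the scatter). Both are large, and both lead towards the limit. Read in reverse, they point to a lower number when an amino group replaces (but-3-yn-1-yl)oxy. However, the groups in those steps, (2-(diethylamino)ethyl)amino and (2-aminoethyl)amino, are not the one entering here, so only part of that size can be carried over. Among the compounds with values here, the data hold no measured compound with (4-ethoxyphenyl)amino. The expected change is a moderate fall in the number, estimated as an at least 4.1-fold lower number from compound 3 to compound 4 (0.61 log units; beyond the scatter). Compound 4 is expected near 12000 nM, with an estimated range of 3000 nM to 45000 nM.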

Compound 4, half-maximal inhibitory concentration: > 50000 nM
Compound 4: no number, only a limit (the forecaster's own chance of this, stated with the estimate: 30%); middle value at least 4.1-fold (0.61 log units) from the limit.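

In this assay compound 4 gives > 50000 nM, which is a limit of the assay and not a number. An amide-type nitrogen at this carbonyl carbon is therefore not enough on its own to give a measurable value, since 4-ethoxyphenyl on that nitrogen brings an at least 14-fold higher number from compound 1 to compound 4 (1.17 log units; beyond the scatter) and an at least 20-fold higher number from compound 2 to compound 4 (1.31 log units; beyond the scatter). The step from compound 3 to compound 4 cannot be read, since both rest on the same ceiling: the limit of > 50000 nM in this assay, at which 2 of the 4 values shown sit.

The compounds shown leave open whether the terminal amine of the chains in compound 1 and compound 2 matters, or the saturated chain itself, and a 2-hydroxyethyl group on the amide-type nitrogen would separate the two. They also leave open whether a 4-aminophenyl group would behave as 4-ethoxyphenyl does.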